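The compounds below may be only part of what the source reports. "The series", "measured", "known", "first", "only" and "open" are said of these compounds alone.

The study concerns a family of related compounds whose antiproliferative activity was measured in a functional assay on MCF7 cells (Homo sapiens) for antiproliferative activity, read by MTT assay, with a stated time of 48 h; a higher number here means a weaker inhibitor, a lower number a stronger inhibitor. Compound 2 `CC(C)=CCC[C@]1(C)/C=C/[C@@H](OC(=O)C=C(C)C)[C@](C)(O)/C=C/C(=O)/C(C(=O)O)=C\C1` gives 16100 nM in this assay, the highest of the three numbers recorded so far. Compound 3 `CC(C)=CCC[C@]1(C)/C=C/[C@@H](OC(=O)C=C(C)C)[C@](C)(O)/C=C/C(=O)/C(C[Si](c2ccccc2)(c2ccccc2)C(C)(C)C)=C\C1` gives 15800 nM in this assay, a number that lies within the scatter of compound 2, so the two cannot be ranked against each other. Compound 1 `CC(=O)O[C@]1(C)/C=C/C(=O)/C(CO)=C\C[C@](C)(CCC=C(C)C)/C=C/[C@H]1OC(=O)C=C(C)C` gives 2320 nM in this assay, a lower number than that of compound 2 by a margin beyond the scatter.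

Compound 4 `CO/N=C/C1=C/C[C@](C)(CCC=C(C)C)/C=C/[C@@H](OC(=O)C=C(C)C)[C@](C)(O)/C=C/C1=O` has not yet been measured. It differs from compound 2 in one place: a group of 4 heavy atoms (2 carbon, 1 nitrogen, 1 oxygen; no ring) in place of a group of 3 heavy atoms (1 carbon, 2 oxygen; no ring), on a double-bonded ring carbon. Among the measured compounds shown here, no step between two measured compounds follows this same change, so nothing measured tells how the carboxy group compares with the group that enters. For the measured compounds named here, the three numbers show only that compound 2 and compound 3 sit high while compound 1 sits lower. For compound 4 the expected step is a 2.0-fold lower number from compound 2 to compound 4 (0.30 log units; within the scatter), a step of modest size toward a lower number, though the data give little to anchor it. The estimate for compound 4 in this assay is 8000 nM, with a range from 2500 nM to 25000 nM.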

Compound 4, half-maximal inhibitory concentration: 2510 nM
For compound 4 the middle estimate is 3.2-fold (0.50 log units) above the measured one; measured number inside the range.
By their numbers in this assay, from the lowest: compounds 1 and 4 (each within the scatter of the next); then compounds 3 and 2 (each within the scatter of the next).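

The exchange of the carboxy group for the open-chain group of 4 heavy atoms (2 carbon, 1 nitrogen, 1 oxygen) on the double-bonded ring carbon gives a 6.4-fold lower number from compound 2 to compound 4 (0.81 log units; beyond the scatter) in this assay. Among the compounds shown here, this is the only step at this position that can be read, and it shows that the number in this assay depends on what this ring carbon carries. By the counts, the carboxy group has 1 hydrogen-bond donor and 1 hydrogen-bond acceptor and the entering group has 0 donors and 2 acceptors, with no net charge on either side, but no measurement on these compounds accounts for the step.

Going by these compounds, this single pair cannot show whether the step follows from the departure of the carboxy group or from the arrival of the new group, and how a methyl ester, a primary amide or a nitrile on this ring carbon would compare remains open. Also open, on these data alone, is whether the same exchange would give a step of similar size on a core that bears an acetyloxy group in place of the hydroxy group.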